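Bromo for chloro in a series at the assay limit

This account rests on a few compounds, and the source may have more. Where it says the series, first, only, none or still open, it means among the compounds named here.

Three related compounds have been tested so far: compound 1 `Nc1nc(=O)n([C@@H]2CS[C@@H](CO)O2)cc1I`, compound 2 `O=c1[nH]c(=O)n([C@@H]2CS[C@@H](CO)O2)cc1Cl` and compound 3 `Cc1cn([C@H]2CS[C@@H](CO)O2)c(=O)nc1N`. The read-out is a functional assay on Vero cells (Chlorocebus sabaeus) for inhibition; a higher number here means a weaker inhibitor, a lower number a stronger inhibitor. Compound 1 gives > 100000 nM, a limit of the assay and not a number. Compound 2 stands at > 100000 nM, also only a limit. Compound 3 gives > 100000 nM, again a limit. Going by the values given here, the series so far therefore shows (the limit of > 100000 nM in this assay, at which 3 of the 3 values shown sit), and no measured pair offers a step to compare.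

Compound 4 `O=c1[nH]c(=O)n([C@@H]2CS[C@@H](CO)O2)cc1Br` comes from compound 2 by one change: bromo in place of chloro on an aromatic carbon. No step beyond the scatter is expected in this assay, in either direction. That expectation rests on compound 2 at > 100000 nM, itself a limit. The estimated step is a number no higher from compound 2 to compound 4 (the limit leaves the size open). Another reported limit is the likeliest outcome. For compound 4 the estimate is 100000 nM, with an expected range of 30000 nM to 300000 nM.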

Compound 4, half-maximal inhibitory concentration: > 100000 nM
Compound 4: only a limit was reported; the forecaster's own chance of this, stated with the estimate: 85%; the middle value sits exactly at the limit.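

No step can be read from compound 2 to compound 4, as both are reported only as limits in this assay: the limit of > 100000 nM in this assay, at which 4 of the 4 values shown sit.

The compounds shown leave open how strongly any of them inhibits in this assay, and whether bromo and chloro differ at all on the shared core.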